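Antiproliferative series: dimethoxyphenyl analogue of a trimethoxyphenyl enone

A few compounds are considered here, and "the series" means these few. Any claim that something is new, unique, unknown or untested is made for them only; others in the source may bear on it.

Of the compounds shown here, two have been measured in a functional assay on DU-145 cells (Homo sapiens) for antiproliferative activity, read by MTT assay, with a stated time of 24 h; on this read-out higher numbers stand for weaker inhibition and lower numbers for stronger inhibition. Compound 1 `COc1ccc(-c2cc(/C=C/C(=O)c3cc(OC)c(OC)c(OC)c3)nc3cc(-c4ccccc4)nn23)cc1OC` gives 8300 nM. Compound 2 `COc1cc(-c2cc(/C=C/C(=O)c3ccccc3)nc3cc(-c4ccccc4)nn23)cc(OC)c1OC` gives 34300 nM, the higher of the two numbers; the gap to compound 1 lies beyond the scatter, so compound 2 is the weaker inhibitor of the pair. Going by the values given here, no pair measured so far differs in a single place, so no step size is yet known from the data.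

Compound 3 `COc1ccc(-c2cc(/C=C/C(=O)c3ccccc3)nc3cc(-c4ccccc4)nn23)cc1OC` follows from compound 2 by one change: hydrogen in place of methoxy on an aromatic carbon. Among the compounds with values here, with no comparable step to lean on, the expected step from compound 2 to compound 3 is a 1.2-fold higher number from compound 2 to compound 3 (0.07 log units; within the scatter), small and without a clear direction, likely within the scatter. In this assay compound 3 is therefore estimated at 40000 nM, within a range from 12000 nM to 130000 nM.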

Compound 3, half-maximal inhibitory concentration: 10000 nM
For compound 3 the middle estimate is 4.0-fold (0.60 log units) above the measured one, outside the stated range (below it).
By their numbers in this assay, from the lowest: compounds 1 and 3 (each within the scatter of the next); then compound 2.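

Taking the ring from 3,4,5-trimethoxyphenyl to 3,4-dimethoxyphenyl gives, in this assay, a 3.4-fold lower number from compound 2 to compound 3 (0.54 log units; beyond the scatter), so hydrogen in place of methoxy on this aromatic carbon is a change this read-out can detect. With the phenyl on the carbonyl carbon, the third methoxy on the other ring goes with weaker inhibition. With the 3,4-dimethoxyphenyl group in place, phenyl in place of 3,4,5-trimethoxyphenyl on the carbonyl carbon gives a 1.2-fold higher number from compound 1 to compound 3 (0.08 log units; within the scatter), so the methoxy groups on that ring make no difference that can be read here.

As far as these compounds go, whether an amine, a carboxylic acid or a fluorine on this aromatic carbon would fit the same trend remains open, as does whether the step holds with 3,4,5-trimethoxyphenyl on the carbonyl carbon. No independent measurement bears on the reason for these results.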